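Swapping the amine on a shared aryloxypropanolamine core

A few compounds are considered here, and "the series" means these few. Any claim that something is new, unique, unknown or untested is made for them only; others in the source may bear on it.

Measured so far:
compound 1, `C#CCN(C)CC(O)COc1ccc(-c2ccccc2)cc1`, gives 100%
compound 2, `C#CCN(C)CC(O)COc1ccc2cc(Br)ccc2c1`, gives 100%

In an assay on isolated protein for inhibition of Amine oxidase [flavin-containing] B (Homo sapiens), read by fluorescence, with a stated time of 1 h, tested at 10 uM (a lower number here means less inhibition, a higher number more inhibition at the concentration tested (going by the name of the read-out)), compound 1 gives 100%. Compound 2 gives 100% in this assay, and the two numbers are level at the digits shown, so nothing separates them within the scatter. Compound 3, `OC(CNC1CC1)COc1ccc(-c2ccccc2)cc1`, has not yet been measured in this assay. Relative to compound 1 it carries cyclopropylamino in place of methyl(propargyl)amino on a saturated chain carbon, two bonds along the chain from an oxygen on a saturated carbon. Within the data shown here, no step between two measured compounds touches this part of the molecule, so there is nothing measured to lean on; the two known values only show that the amine found in compound 1 and compound 2 sits at the top of the scale. With no guide, a drop from compound 1 is expected rather than none, though its size is uncertain. Compound 3 is estimated to give 60%, with a range of 20% to 95%, meaning an expected step of a number 40 percentage points lower from compound 1 to compound 3 (beyond the scatter).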

Compound 3, a percentage reported as inhibition, at one concentration (the size of the read-out at that concentration, not a potency): 100%
For compound 3 the middle estimate is 40 percentage points below the measured one; measured number outside the range, above it.
By their numbers in this assay, from the lowest: compounds 1, 2 and 3 (each within the scatter of the next).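

In this assay, putting cyclopropylamino in place of methyl(propargyl)amino on a saturated chain carbon gives no change at the digits printed from compound 1 to compound 3 (within the scatter) and so shows that the triple bond of the methyl(propargyl)amino group is not required for a reading at the top of the scale. Both compounds sit at that top and the read-out comes from a single concentration, so any difference in potency between them stays hidden. Among these compounds, nothing measured so far explains why this change leaves the reading in place.

Still open, from the compounds shown here alone, is how far this position can be changed with the reading staying level: a dimethylamino group, a piperidine ring or a carboxylic acid there could show where the reading starts to fall. Testing at lower concentrations could also reveal whether compound 1 and compound 3 truly match.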